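The source may hold more compounds than are shown below. What is called first, only, known or untested is meant among the compounds shown, and "the series" means these compounds.

Measured in an assay on cells for displacement of a labelled ligand from prostaglandin E2 receptor EP4 subtype (Homo sapiens), read by scintillation counting (on this read-out higher numbers stand for weaker inhibition and lower numbers for stronger inhibition), two compounds are known:

Compound 1 `Cc1oc(C(=O)O)cc1COc1ccc(-c2ccc(Cl)cc2)cc1`: 1000 nM
Compound 2 `COc1ccc(-c2ccc(OCc3cc(C(=O)NS(=O)(=O)c4cccs4)oc3C)cc2)cc1`: 3.6 nM

Compound 1 stands at the higher of these two numbers. Compound 2 differs from it in more than one place, so the gap between them cannot be tied to a single change; the two values simply show that compound 2 sits far lower than compound 1 in this assay, well beyond the scatter.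

Compound 3 `Cc1oc(C(=O)O)cc1COc1ccc(-c2nnco2)cc1` is not yet measured. It differs from compound 1 in one place: 1,3,4-oxadiazol-2-yl in place of 4-chlorophenyl on an aromatic carbon. For the measured compounds named here, no measured pair shows this kind of change, so there is no direct guide to its size. Compound 1 is the only anchor, giving 1000 nM in this assay. The step from compound 1 to compound 3 is expected to be modest and toward weaker inhibition, a 3.0-fold higher number from compound 1 to compound 3 (0.48 log units; beyond the scatter), though a change within the scatter cannot be excluded. For compound 3 the estimate is 3000 nM, with a likely range from 700 nM to 15000 nM.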

Compound 3, inhibition constant: > 10000 nM
Compound 3 was reported as a limit; the forecaster's own chance of this, stated with the estimate: 15%; at least 3.3-fold (0.52 log units) between middle value and limit.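

Putting 1,3,4-oxadiazol-2-yl in place of 4-chlorophenyl on this aromatic carbon gives, in this assay, an at least 10-fold higher number from compound 1 to compound 3 (1.00 log units; beyond the scatter). For the compounds shown here, this is the first change at this position that can be read alone, as compound 1 and compound 2 differ in more than one place. The value of compound 3 is a limit and not a number, so the step has no known upper end: the limit of > 10000 nM in this assay, at which 1 of the 3 values shown sits.

The compounds shown leave open which part of the change counts: the lost chlorine, the smaller ring or its hetero atoms, which an unsubstituted phenyl or a pyridine ring at this place would begin to separate. Also open, on these data alone, is what an acyl sulfonamide in place of the carboxylic acid does on its own, with the 4-chlorophenyl kept.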